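Fluoro for chloro on the core of a sulfonyl series

The compounds below may be only part of what the source reports. "The series", "measured", "known", "first", "only" and "open" are said of these compounds alone.

Measured so far:
compound 1 `CC1CCN(c2c(S(=O)(=O)c3ccc(F)c(Cl)c3)cnc3cc(F)ccc23)CC1` — 94%
compound 2 `COc1cccc(S(=O)(=O)c2cnc3cc(Cl)ccc3c2N2CCC(C)CC2)c1` — 93%

In an assay on isolated protein for displacement of a labelled ligand from metabotropic glutamate receptor 5 (Homo sapiens), with a stated time of 60 min, tested at 1 uM (a higher number here means more inhibition at the concentration tested (going by the name of the read-out), a lower number less inhibition), compound 1 gives 94% and compound 2 gives 93%; the two numbers lie within the scatter of each other, so compound 2 stands on the same level as compound 1. Within the data shown here, no step between measured compounds that differ in one place is available. Compound 3 `COc1cccc(S(=O)(=O)c2cnc3cc(F)ccc3c2N2CCC(C)CC2)c1` differs from compound 2 by fluoro in place of chloro on an aromatic carbon. On the strength of compound 2 at 93% and compound 1 at 94%, both carrying the same core with either halogen, no step beyond the scatter is expected in this assay. The expected step of a number 2 percentage points lower from compound 2 to compound 3 (within the scatter) is small. Compound 3 is estimated at 91%, between 80% and 98%.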

Compound 3, a percentage reported as inhibition, at one concentration (the size of the read-out at that concentration, not a potency): 90%
Estimate against measurement, compound 3: 1 percentage points above; measured number inside the range.
By their numbers in this assay, from the lowest: compounds 3, 2 and 1 (each within the scatter of the next).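

In this assay, fluoro in place of chloro on an aromatic carbon of the core gives a number 3 percentage points lower from compound 2 to compound 3 (within the scatter), so with 3-methoxyphenyl on the sulfonyl sulfur this position accepts either halogen. With fluoro held on the core, 3-methoxyphenyl in place of 3-chloro-4-fluorophenyl gives a number 4 percentage points lower from compound 1 to compound 3 (within the scatter), so neither single change moves the read-out beyond the scatter at this one concentration. From the compounds shown here alone, whether hydrogen, methyl or a nitrile on this carbon would hold the number stays open. No measured evidence bears on the reason for either step.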